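The compounds below may be only part of what the source reports. "The series", "measured", "known", "first", "only" and "open" are said of these compounds alone.

Going by the values given here, in a functional assay on HepG2 cells (Homo sapiens) for inhibition, read by MTT assay (a lower number here means a stronger inhibitor, a higher number a weaker inhibitor), compound 1 `COc1cc2ncnc(Nc3ccc(NC(=O)c4cccc(F)c4)cc3)c2cc1OC` gives 8200 nM and compound 2 `COc1cc2ncnc(Nc3ccc(NC(=O)c4ccccc4Cl)cc3)c2cc1OC` gives 26000 nM, the higher of the two numbers so far. Compound 3 `COc1cc2ncnc(Nc3ccc(NC(=O)c4ccc(I)cc4)cc3)c2cc1OC` differs from compound 2 on the carbonyl carbon: 4-iodophenyl in place of 2-chlorophenyl on a carbonyl carbon. Among the compounds with values here, the only measured step bearing on this, a 3.2-fold higher number from compound 1 to compound 2 (0.50 log units; beyond the scatter), is a modest one that also exchanges the substituted phenyl on that carbonyl carbon. Within the data shown here, no measured compound carries iodine, so the guidance is thin. A modest move towards a lower number is expected in this assay, although a result within the scatter would not surprise. The expected step is a 1.9-fold lower number from compound 2 to compound 3 (0.27 log units; within the scatter). For compound 3 the estimate is 14000 nM, with an expected range of 5500 nM to 32000 nM.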

Compound 3, half-maximal inhibitory concentration: 40000 nM
For compound 3 the middle estimate is 2.9-fold (0.46 log units) below the measured one; measured number outside the range, above it.
By their numbers in this assay, from the lowest: compound 1; then compounds 2 and 3 (each within the scatter of the next).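

In this assay, 4-iodophenyl and 2-chlorophenyl on the carbonyl carbon do not separate (a 1.5-fold higher number from compound 2 to compound 3 (0.19 log units; within the scatter)), whereas 4-iodophenyl and 3-fluorophenyl do (a 4.9-fold higher number from compound 1 to compound 3 (0.69 log units; beyond the scatter)). Compound 1 therefore stands apart from both compound 2 and compound 3, while those two stay together despite carrying different halogens at different ring positions. Nothing on hand gives a reason for this. Open is whether the lower number of compound 1 goes with fluorine or with the place of its substituent, since the compounds shown hold neither fixed. Also open, from the compounds shown here alone, is how a carboxylic acid or an aminomethyl group on that phenyl would read.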